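This account rests on a few compounds, and the source may have more. Where it says the series, first, only, none or still open, it means among the compounds named here.

Compound 1 `O=Cc1ccc(-c2cn3ccnc3c(-c3ccc4ncn(C5CCCCC5)c4c3)n2)cc1` and compound 2 `CC(=O)c1ccc(-c2cn3ccnc3c(-c3ccc4ncn(C5CCCCC5)c4c3)n2)cc1` share one core and differ only at the end of the side chain. In a functional assay on RPMI-8226 cells (Homo sapiens) for inhibition, read by sulforhodamine B assay, with a stated time of 48 h, tested at 10 uM (on this read-out higher numbers stand for more inhibition at the one concentration tested (going by the name of the read-out) and lower numbers for less inhibition), compound 1 gives 82.5%, while compound 2 gives 20.8%, the lower of the two numbers; the change a number 61.7 percentage points lower from compound 1 to compound 2 (beyond the scatter). Compound 3 `Clc1ccc(-c2cn3ccnc3c(-c3ccc4ncn(C5CCCCC5)c4c3)n2)cc1` differs from compound 2 by chloro in place of acetyl on an aromatic carbon. No measured step exchanges a carbonyl group for a halogen, so the single step shown, which altered only the substituent on the carbonyl carbon, gives little guidance here. The expected step is a number 14.2 percentage points higher from compound 2 to compound 3 (beyond the scatter), with wide uncertainty. Compound 3 is therefore estimated at 35%, within 5% to 75%.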

Compound 3, a percentage reported as inhibition, at one concentration (the size of the read-out at that concentration, not a potency): 19%
Compound 3: middle estimate off by 16 percentage points, on the high side; measured number inside the range.
By their numbers in this assay, from the lowest: compounds 3 and 2 (each within the scatter of the next); then compound 1.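

In this assay, chloro in place of acetyl gives a number 1.8 percentage points lower from compound 2 to compound 3 (within the scatter) and so shows that two quite different groups can read alike at this place on the ring, one with a carbonyl and one without. Formyl stands apart from chloro as well, with a number 63.5 percentage points lower from compound 1 to compound 3 (beyond the scatter) on going from one to the other. Nothing available explains why formyl alone gives the high number. Going by these compounds, whether that high number is special to formyl stays open. A carboxylic acid, a nitrile or a hydroxymethyl group at this place could help to settle it.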